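This account rests on a few compounds, and the source may have more. Where it says the series, first, only, none or still open, it means among the compounds named here.

Of the compounds shown here, two of a shared core have been measured in an assay on HEK293-A cells for agonist activity at probable G-protein coupled receptor 34 (Mus musculus), with a stated time of 1.5 h; on this read-out lower numbers stand for smaller maximal responses and higher numbers for larger maximal responses. Compound 1, `Cc1ccc(Oc2cccc(COc3ccccc3CCC(=O)O[C@@H]3CCCO[C@@H]3COP(=O)(O)OC[C@H](N)C(=O)O)c2)cc1`, gives in this assay a value of 16%. Compound 2, `N[C@@H](COP(=O)(O)OC[C@H]1OCCC[C@H]1OC(=O)CCc1ccccc1OCc1cccc(Oc2ccccc2)c1)C(=O)O`, carries hydrogen in place of methyl on an aromatic carbon and gives in this assay a value of 17.7%. For the measured compounds named here, the single measured step, a number 1.7 percentage points higher from compound 1 to compound 2 (within the scatter), lies within the scatter, so compound 2 stands alongside compound 1 with no difference between them that can be read as real.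

Compound 3, `N[C@@H](COP(=O)(O)OC[C@H]1OCCC[C@H]1OC(=O)CCc1ccccc1OCc1cccc(Oc2ccc(Cl)cc2)c1)C(=O)O`, has not been measured in this assay. It differs from compound 2 by chloro in place of hydrogen on an aromatic carbon, placed on an aromatic carbon of a six-membered aromatic ring of carbon only, para to a large group. Going by the values given here, the only step that could bear on this change is a number 1.7 percentage points higher from compound 1 to compound 2 (within the scatter), which concerns a different group on a different ring and was itself within the scatter. The data therefore give no ground for expecting a change in this assay beyond the scatter, in either direction, and the expected step is a number 0.3 percentage points higher from compound 2 to compound 3 (within the scatter). Compound 3 is accordingly estimated at 18%, with a range from 8% to 32%.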

Compound 3, largest response reached (Emax), in percent of the reference or control that the assay uses: 15.1%
Compound 3: the middle estimate sits 2.9 percentage points above what was measured, and the stated range covers the measured number.
By their numbers in this assay, from the lowest: compounds 3, 1 and 2 (each within the scatter of the next).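

The change now has a direct reading at this position: in this assay, chloro in place of hydrogen on an aromatic carbon of the six-membered aromatic ring of carbon only, para to a large group, gives a number 2.6 percentage points lower from compound 2 to compound 3 (within the scatter). The comparison with the methyl group at the same place is also available, and chloro in place of methyl gives a number 0.9 percentage points lower from compound 1 to compound 3 (within the scatter). Hydrogen, methyl and chloro at this carbon therefore cannot be told apart on this read-out, which the single earlier step could show only for hydrogen and methyl, and no measurement at hand explains this result.

The compounds shown cover only these three small substituents, so it remains open whether a methoxy group, an amine or a carboxylic acid at this carbon would move the maximal response beyond the scatter. They also leave open whether a 4-chlorophenoxy group would read the same way with changes elsewhere on the shared core, such as a longer chain in place of the present one.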